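Replacing a chloro-bearing ring with a hydroxy-bearing one

This account rests on a few compounds, and the source may have more. Where it says the series, first, only, none or still open, it means among the compounds named here.

Of the compounds shown here, three sharing one core have been measured in a functional assay on T47D cells (Homo sapiens) for inhibition, read by CCK-8 assay, with a stated time of 72 h, tested at 1 uM; on this read-out higher numbers stand for more inhibition of growth at the one concentration tested and lower numbers for less inhibition of growth. Compound 1 `CN(C)C(=O)c1cc2cnc(Nc3ccc(NC(=O)C4(C(=O)Nc5ccccc5)CC4)cc3)nc2n1C1CCCC1` gives 52.8%, compound 2 `CN(C)C(=O)c1cc2cnc(Nc3ccc(NC(=O)C4(C(=O)Nc5cccc(O)c5)CC4)cc3)nc2n1C1CCCC1` gives 80.7%, and compound 3 `CN(C)C(=O)c1cc2cnc(Nc3ccc(NC(=O)C4(C(=O)Nc5cccc(Cl)c5)CC4)cc3)nc2n1C1CCCC1` gives 39.3%, the lowest of the three. The steps run a number 13.5 percentage points lower from compound 1 to compound 3 (beyond the scatter) and a number 41.4 percentage points lower from compound 2 to compound 3 (beyond the scatter), while hydroxy in place of hydrogen gave a number 27.9 percentage points higher from compound 1 to compound 2 (beyond the scatter).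

Compound 4 `CN(C)C(=O)c1cc2cnc(Nc3ccc(NC(=O)C4(C(=O)Nc5ccc(O)cc5)CC4)cc3)nc2n1C1CCCC1` differs from compound 3 by 4-hydroxyphenyl in place of 3-chlorophenyl on an amide-type nitrogen. Both relevant steps point the same way: removing chloro and adding hydroxy each raised inhibition, so a sizeable rise is expected, with the hydroxy now on a different ring carbon than in compound 2. Compound 4 is therefore estimated at 70%, within 48% to 88%, an expected step of a number 30.7 percentage points higher from compound 3 to compound 4 (beyond the scatter).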

Compound 4, percent growth inhibition at one concentration: 91.5%
Compound 4: the middle estimate sits 21.5 percentage points below what was measured, and the stated range ends below it.
By their numbers in this assay, from the lowest: compound 3; then compound 1; then compound 2; then compound 4.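

In this assay, moving the hydroxy to give 4-hydroxyphenyl on the amide-type nitrogen produces a number 10.8 percentage points higher from compound 2 to compound 4 (beyond the scatter), so the ring carbon that carries the hydroxy matters, not only its presence. Set against the plain phenyl ring, this hydroxy gives a number 38.7 percentage points higher from compound 1 to compound 4 (beyond the scatter), and set against 3-chlorophenyl, it gives a number 52.2 percentage points higher from compound 3 to compound 4 (beyond the scatter). Nothing available explains why the hydroxy raises inhibition of growth. Still open, going by these compounds, is whether a methoxy, an amine or a carboxylic acid in this place can match the hydroxy. Also open, on these data alone, is how 4-chlorophenyl compares with 3-chlorophenyl.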